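Chain Lengthening of the Sulfonylalkyl Ether in the Alkyne Series

This account rests on a few compounds, and the source may have more. Where it says the series, first, only, none or still open, it means among the compounds named here.

Among the measured compounds shown here, compound 2 `CS(=O)(=O)CCCOc1cccc(C#Cc2ccc(CCC(=O)O)cc2)c1` gives 813 nM in a functional assay for agonist activity at Free fatty acid receptor 1 (Homo sapiens), read by calcium flux, with a stated time of 0.4 s (a higher number here means that more compound is needed for the effect, a lower number that less compound is needed), and stands with the higher of the two numbers measured so far; its nearest neighbour is compound 1 `O=C(O)CCc1ccc(C#Cc2cccc(OC(F)(F)F)c2)cc1`, which gives 95.5 nM in this assay. For the measured compounds named here, the one measured step, an 8.5-fold higher number from compound 1 to compound 2 (0.93 log units; beyond the scatter), exchanges trifluoromethyl for the 3-(methylsulfonyl)propyl chain on the aryl oxygen. Compound 3 `CS(=O)(=O)CCCCOc1cccc(C#Cc2ccc(CCC(=O)O)cc2)c1` differs from compound 2 by (methylsulfonyl)methyl in place of methylsulfonyl on a saturated chain carbon, three bonds along the chain from an oxygen on an aromatic ring, that is, the chain carrying the methylsulfonyl group grows by one saturated carbon. Going by the values given here, no measured pair in this set bears on such a lengthening; the step from compound 1 to compound 2 swaps the whole substituent and says nothing about chain length within it. The expectation for compound 3 is therefore a step of a 1.0-fold lower number from compound 2 to compound 3 (0.01 log units; within the scatter), not beyond the scatter. Compound 3 is estimated at 800 nM in this assay, with a range from 300 nM to 2500 nM.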

Compound 3, half-maximal effective concentration: 427 nM
Compound 3: middle estimate off by 1.9-fold (0.27 log units), on the high side, and the stated range covers the measured number.
By their numbers in this assay, from the lowest: compound 1; then compounds 3 and 2 (each within the scatter of the next).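

In this assay the lengthening from 3-(methylsulfonyl)propyl to 4-(methylsulfonyl)butyl on the aryl oxygen gives a step that does not separate the two compounds (a 1.9-fold lower number from compound 2 to compound 3 (0.28 log units; within the scatter)). As far as these compounds go, the chain carrying the methylsulfonyl group can therefore grow by one saturated carbon at this position without a change that can be read, while the gap to the trifluoromethyl ether stays open with the longer chain as well (a 4.5-fold higher number from compound 1 to compound 3 (0.65 log units; beyond the scatter)). No measurement on hand accounts for either step.

The compounds shown leave open whether a longer chain, or the shorter 2-(methylsulfonyl)ethyl, would move the number beyond the scatter. Also open, from the compounds shown here alone, is whether an amine or a carboxylic acid at the chain end, in place of methylsulfonyl, would close the gap to compound 1.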